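Swapping furan for thiophene on a dihydropyrimidinone

The compounds below may be only part of what the source reports. "The series", "measured", "known", "first", "only" and "open" are said of these compounds alone.

Measured compounds:
- compound 1, `CC1=C(C(=O)OCC(C)C)C(c2cccs2)NC(=O)N1`, 11% in an assay on membranes from HeLa cells for displacement of a labelled ligand from adenosine receptor A3 (Homo sapiens), read by scintillation counting, with a stated time of 180 min, tested at 1 uM; on this read-out higher numbers stand for more inhibition at the one concentration tested (going by the name of the read-out) and lower numbers for less inhibition
- compound 2, `CC1=C(C(=O)OC(C)(C)C)C(c2cccs2)NC(=O)N1`, 7% in this assay
- compound 3, `CC1=C(C(=O)NC(C)C)C(c2ccco2)NC(=O)N1`, 4% in this assay

Compound 3 gives the lowest of the three numbers in this assay, but its gap to compound 2 and its gap to compound 1 both lie within the scatter, so no order among the three can be read from them. Compound 4, `CC1=C(C(=O)NC(C)C)C(c2cccs2)NC(=O)N1`, is not yet measured. The change from compound 3 to compound 4 is thiophen-2-yl in place of furan-2-yl on a saturated ring carbon.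

Within the data shown here, no measured pair shows this exact change. Among the measured compounds shown here, the only measured step, a number 4 percentage points lower from compound 1 to compound 2 (within the scatter), concerns a different position and stays within the scatter. Compounds 1 and 2, which already carry the entering thiophen-2-yl group, give numbers close to that of compound 3. Taken together these three values suggest that the step in this assay will stay within the scatter, with no clear direction.

Compound 4 is therefore expected to give about 7% in this assay, within a range from 0% to 18%. The step this expectation implies is a number 3 percentage points higher from compound 3 to compound 4 (within the scatter), estimated to lie within the scatter.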

Compound 4, a percentage reported as inhibition, at one concentration (the size of the read-out at that concentration, not a potency): 1%
Estimate against measurement, compound 4: 6 percentage points above, within the range that was stated.
By their numbers in this assay, from the lowest: compounds 4, 3, 2 and 1 (each within the scatter of the next).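

In this assay, the swap at this position, thiophen-2-yl in place of furan-2-yl on a saturated ring carbon, gives a number 3 percentage points lower from compound 3 to compound 4 (within the scatter) with the isopropylcarbamoyl group held in place, so exchanging these two rings changes nothing that can be read here. With thiophen-2-yl held fixed, the group on the carbonyl carbon gives a similar picture: isopropylamino in place of tert-butoxy gives a number 6 percentage points lower from compound 2 to compound 4 (within the scatter) and isopropylamino in place of isobutoxy gives a number 10 percentage points lower from compound 1 to compound 4 (within the scatter), both too small to read as real changes. No measurement here offers an explanation for these numbers.

Going by these compounds, whether a phenyl ring or a pyridine ring on the same saturated ring carbon would lift the number remains open. So does the outcome with a carboxylic acid or a longer chain on the carbonyl carbon.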